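Working notes: extending compound 2 on the aromatic ring

The source may hold more compounds than are shown below. What is called first, only, known or untested is meant among the compounds shown, and "the series" means these compounds.

Measured so far:
compound 1 `CC(=O)Nc1ccc(-c2nc(N3CC4CCC(C3)O4)c3sccc3n2)cc1`: 1700 nM
compound 2 `O=C(Nc1ccc(-c2nc(N3CC4CCC(C3)O4)c3sccc3n2)cc1)NC1CC1`: 40 nM
compound 3 `CNC(=O)Nc1ccc(-c2nc(N3CC4CCC(C3)O4)c3sccc3n2)cc1`: 85 nM

In a functional assay on LNCaP cells (Homo sapiens) for cytotoxicity (on this read-out lower numbers stand for stronger inhibition and higher numbers for weaker inhibition), compound 2 holds the lowest number of the three. The nearest measured step is a 2.1-fold higher number from compound 2 to compound 3 (0.33 log units; beyond the scatter), the furthest is a 43-fold lower number from compound 1 to compound 2 (1.63 log units; beyond the scatter), and alongside stands a 20-fold lower number from compound 1 to compound 3 (1.30 log units; beyond the scatter). All three concern the carbonyl carbon or the amide-type nitrogen of the acyl group on the aniline. Compound 4 `CN1CCN(Cc2cc3nc(-c4ccc(NC(=O)NC5CC5)cc4)nc(N4CC5CCC(C4)O5)c3s2)CC1` differs from compound 2 elsewhere: (4-methylpiperazin-1-yl)methyl in place of hydrogen on an aromatic carbon. Among the compounds with values here, no measured step touches that aromatic carbon, so the series gives no direct guide for this change. The expectation for compound 4 is therefore a step of no change at the digits printed from compound 2 to compound 4 (within the scatter), not beyond the scatter. Compound 4 is estimated at 40 nM, with a range from 12 nM to 130 nM.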

Compound 4, half-maximal inhibitory concentration: 400 nM
Compound 4: middle estimate off by 10-fold (1.00 log units), on the low side; the whole stated range lies below it.
By their numbers in this assay, from the lowest: compound 2; then compound 3; then compound 4; then compound 1.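

In this assay, the aromatic carbon next to the ring sulfur proves sensitive to substitution: (4-methylpiperazin-1-yl)methyl in place of hydrogen gives a 10-fold higher number from compound 2 to compound 4 (1.00 log units; beyond the scatter). Within the data shown here, this is the only reading at this position, as the earlier steps all concerned the acyl group on the aniline. No evidence at hand accounts for the size of this step.

Going by these compounds, it remains open whether a plain methyl or a morpholin-4-ylmethyl group at this carbon would stay closer to compound 2. Also open, on these data alone, is whether the step carries over to compound 3.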